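Fluorine on the Benzyl Ring: Expectation for Compound 4

The source may hold more compounds than are shown below. What is called first, only, known or untested is meant among the compounds shown, and "the series" means these compounds.

Compound 1, `CC(C(=O)NCc1ccc(C(F)(F)F)cc1N1CCC(Cc2ccccc2)CC1)c1ccc(NS(C)(=O)=O)c(F)c1`: 1.4 nM
Compound 2, `CC(C(=O)NCc1ccc(C(F)(F)F)cc1N1CCC(Cc2ccc(F)cc2)CC1)c1ccc(NS(C)(=O)=O)c(F)c1`: 0.4 nM
Compound 3, `CC(C(=O)NCc1ccc(C(F)(F)F)cc1OCc1ccccc1)c1ccc(NS(C)(=O)=O)c(F)c1`: 0.9 nM

These three compounds were measured in an assay on CHO cells for antagonist activity at transient receptor potential cation channel subfamily V member 1 (Homo sapiens), read by FLIPR; a higher number here means a weaker inhibitor, a lower number a stronger inhibitor. Compound 2 differs from compound 1 by fluoro in place of hydrogen on an aromatic carbon, and this change gave a 3.5-fold lower number from compound 1 to compound 2 (0.54 log units; beyond the scatter). Compound 3 carries a different core; the difference between the core of compound 1 and the core of compound 3 is not broken down here. In this assay compound 3 and compound 1 lie within the scatter of each other, while compound 2 sits at a lower number than both.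

Compound 4, `CC(C(=O)NCc1ccc(C(F)(F)F)cc1OCc1ccc(F)cc1)c1ccc(NS(C)(=O)=O)c(F)c1`, has not yet been measured. It differs from compound 3 by fluoro in place of hydrogen on an aromatic carbon, the same change as that from compound 1 to compound 2, at a place described in the same words. Since the earlier step was a 3.5-fold lower number from compound 1 to compound 2 (0.54 log units; beyond the scatter), a step of similar size is expected here, though its transfer to the core of compound 3 is not assured. The step from compound 3 to compound 4 is estimated at a 2.6-fold lower number from compound 3 to compound 4 (0.41 log units; beyond the scatter). Compound 4 is therefore expected to give about 0.35 nM, plausibly between 0.15 nM and 0.9 nM.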

Compound 4, inhibition constant: 0.5 nM
Compound 4: middle estimate off by 1.4-fold (0.15 log units), on the low side; the range from low to high includes it.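

In this assay, the exchange of hydrogen for fluoro on the benzyloxy group gave a 1.8-fold lower number from compound 3 to compound 4 (0.26 log units; within the scatter) and so, taken alone, this step on the core of compound 3 cannot be told from no change at all. The result fits the change carrying over from one core to the other, but it does not prove that it does, since only two cores are shown and the second step is too small to stand clear of the scatter; a real difference in size between the cores is neither shown nor ruled out. Set side by side, the two steps cannot be told apart: the same change on two cores in this assay, a 3.5-fold lower number (0.54 log units; beyond the scatter) from compound 1 to compound 2 and a 1.8-fold lower number (0.26 log units; within the scatter) from compound 3 to compound 4, 1.9-fold (0.29 log units) apart, within the scatter of two such steps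

The compounds shown leave open whether chloro, methyl or a nitrile in the place of fluoro would behave alike on these two cores. They also leave open whether the step would hold if an amine or a longer chain replaced the benzyloxy group.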